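This account rests on a few compounds, and the source may have more. Where it says the series, first, only, none or still open, it means among the compounds named here.

Measured so far in an assay for inhibition of RAC-alpha serine/threonine-protein kinase (Homo sapiens), read by HTRF, with a stated time of 1 h; a lower number here means a stronger inhibitor, a higher number a weaker inhibitor:

Compound 1 `Cn1ncc(Cl)c1-c1cc(C(=O)N[C@@H]2CN[C@H](CC(O)CO)C[C@H]2c2ccc(Cl)c(Cl)c2)oc1Cl`: 3.79 nM
Compound 2 `Cn1ncc(Cl)c1-c1cc(C(=O)N[C@@H]2CN[C@H](CC(=O)O)C[C@H]2c2ccc(Cl)c(Cl)c2)oc1Cl`: 1.94 nM
Compound 3 `CCC[C@@H]1C[C@@H](c2ccc(Cl)c(Cl)c2)[C@H](NC(=O)c2cc(-c3c(Cl)cnn3C)c(Cl)o2)CN1`: 10.4 nM

All three share one core and differ only in the group carried on a saturated chain carbon bound to a saturated ring carbon. Compound 1 carries a 1,2-dihydroxyethyl group there and stands second highest of the three numbers. Its nearest neighbour is compound 2, with a 2.0-fold lower number from compound 1 to compound 2 (0.29 log units; within the scatter), a difference that does not exceed the scatter of repeated measurements. The furthest is compound 3, with a 2.7-fold higher number from compound 1 to compound 3 (0.44 log units; beyond the scatter), and from compound 2 to compound 3 the gap is a 5.4-fold higher number from compound 2 to compound 3 (0.73 log units; beyond the scatter).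

Compound 4 `Cn1ncc(Cl)c1-c1cc(C(=O)N[C@@H]2CN[C@H](CC(=O)NC3CCC3)C[C@H]2c2ccc(Cl)c(Cl)c2)oc1Cl` is the next step from compound 1. The change is cyclobutylcarbamoyl in place of 1,2-dihydroxyethyl on a saturated chain carbon bound to a saturated ring carbon.

Among the measured compounds shown here, none of the measured steps brings in an amide; the only steps that speak to this position are the three above, and they show that exchanging the 1,2-dihydroxyethyl group for carboxy moves the number little, while exchanging it for ethyl makes it modestly higher. The step of a 1.5-fold higher number from compound 1 to compound 4 (0.16 log units; within the scatter) is therefore expected to be small, leaning toward a higher number. Compound 4 is estimated at 5.5 nM, within a range from 1.8 nM to 17 nM.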

Compound 4, half-maximal inhibitory concentration: 7.98 nM
For compound 4 the middle estimate is 1.5-fold (0.16 log units) below the measured one; the range from low to high includes it.
By their numbers in this assay, from the lowest: compounds 2 and 1 (each within the scatter of the next); then compounds 4 and 3 (each within the scatter of the next).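

In this assay, among the compounds shown here, the change to cyclobutylcarbamoyl gives a 2.1-fold higher number from compound 1 to compound 4 (0.32 log units; beyond the scatter) and this is the first look at an amide on a saturated chain carbon bound to a saturated ring carbon: the number moves up modestly, past the scatter, whereas the change to carboxy did not move it past the scatter. The comparison with the carboxy compound is the most direct, since cyclobutylamino in place of hydroxy on the carbonyl carbon gives a 4.1-fold higher number from compound 2 to compound 4 (0.61 log units; beyond the scatter) and so the carbonyl carbon alone does not hold the number at the level of compound 2. Set against the plain chain, the amide gives a 1.3-fold lower number from compound 3 to compound 4 (0.12 log units; within the scatter) and so, even with its added ring, it cannot be told apart from the ethyl group of compound 3 in this assay.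

The compounds shown leave open whether a smaller amide such as methylcarbamoyl, or an amine such as aminomethyl at the same place, would sit nearer compound 2 or nearer compound 3, and so whether the cyclobutyl ring or the amide link sets the number. Nothing measured here gives a reason for any of these steps.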